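Two Methoxy Substitutions on a Shared Benzamide Core

This account rests on a few compounds, and the source may have more. Where it says the series, first, only, none or still open, it means among the compounds named here.

Measured compounds:
compound 1, `COc1ccc(C(=O)Nc2ccc(N(C)S(C)(=O)=O)c(OCc3cc(Cl)ccc3Cl)c2)cc1`, 490 nM
compound 2, `COc1ccc(C(=O)Nc2ccc(N(C)S(C)(=O)=O)c(OCc3cc(Cl)ccc3Cl)c2)cc1OC`, 3730 nM
compound 3, `COc1ccc(C(=O)Nc2ccc(N(C)S(C)(=O)=O)c(OCc3cc(C(F)(F)F)ccc3C)c2)cc1`, 2030 nM

All three were tested in a functional assay on SK-BR-3 cells (Homo sapiens) for antiproliferative activity, read by MTT assay, with a stated time of 48 h; on this read-out lower numbers stand for stronger inhibition and higher numbers for weaker inhibition. Compound 1 gives the lowest number of the three. Going from compound 1 to compound 2, the change is methoxy in place of hydrogen on an aromatic carbon, and this gives a 7.6-fold higher number from compound 1 to compound 2 (0.88 log units; beyond the scatter). Compound 3 differs from compound 1 by 2-methyl-5-(trifluoromethyl)phenyl in place of 2,5-dichlorophenyl on a saturated chain carbon bound to an oxygen on an aromatic ring, which gives a 4.1-fold higher number from compound 1 to compound 3 (0.62 log units; beyond the scatter).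

Compound 4, `COc1ccc(C(=O)Nc2ccc(N(C)S(C)(=O)=O)c(OCc3cc(C(F)(F)F)ccc3C)c2)cc1OC`, has not been measured. It differs from compound 3 by methoxy in place of hydrogen on an aromatic carbon. For the measured compounds named here, this is the same change that was made from compound 1 to compound 2, at a place described in the same words, so the earlier step is the only guide available here. The two cores differ as told by 2-methyl-5-(trifluoromethyl)phenyl in place of 2,5-dichlorophenyl on a saturated chain carbon bound to an oxygen on an aromatic ring. Since compound 3 already stands at 2030 nM, the expected step to compound 4 in this assay is a 5.9-fold higher number from compound 3 to compound 4 (0.77 log units; beyond the scatter), close to the earlier one but not assumed to repeat exactly. The estimate for compound 4 in this assay is therefore 12000 nM, with a range from 4000 nM to 40000 nM.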

Compound 4, half-maximal inhibitory concentration: 16900 nM
For compound 4 the middle estimate is 1.4-fold (0.15 log units) below the measured one, within the range that was stated.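

In this assay, going from 4-methoxyphenyl to 3,4-dimethoxyphenyl gives an 8.3-fold higher number from compound 3 to compound 4 (0.92 log units; beyond the scatter), and this step keeps its size when carried from the core of compound 1 to the core of compound 3: the same change on two cores in this assay, a 7.6-fold higher number (0.88 log units; beyond the scatter) from compound 1 to compound 2 and an 8.3-fold higher number (0.92 log units; beyond the scatter) from compound 3 to compound 4, 1.1-fold (0.04 log units) apart, within the scatter of two such steps

The other change, 2-methyl-5-(trifluoromethyl)phenyl in place of 2,5-dichlorophenyl, gives a 4.5-fold higher number from compound 2 to compound 4 (0.66 log units; beyond the scatter), and it also keeps its size whichever benzamide carries it: the same change on two cores in this assay, a 4.1-fold higher number (0.62 log units; beyond the scatter) from compound 1 to compound 3 and a 4.5-fold higher number (0.66 log units; beyond the scatter) from compound 2 to compound 4, 1.1-fold (0.04 log units) apart, within the scatter of two such steps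

Within these four compounds the two changes therefore behave independently, each raising the number by about the same amount whatever the other part of the molecule is, but this rests on just two pairs in a single cell assay and shows neither why the number rises nor that the same would hold on a different core.

On these data alone, it remains open whether a smaller or different group at the same place, such as a fluorine, a hydroxyl or an amine, would raise the number as much as methoxy does. As far as these compounds go, it is also open whether replacing the 4-methoxy group itself, for instance with a chlorine or a carboxylic acid, would lower the number further.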